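The source may report more compounds than this note shows. Statements on the series, on what has been measured and on what is new or still open speak of the compounds shown alone.

Measured so far in a functional assay for agonist activity at G protein-coupled receptor 88 (Homo sapiens), read by HTRF and cAMP accumulation; on this read-out lower numbers stand for an effect already at smaller amounts and higher numbers for an effect only at larger amounts of compound:
compound 1, `CC[C@H](C)[C@H](N)CN(C(=O)[C@@H]1C[C@H]1c1ccc(Cl)cc1)c1ccc(-c2ccccc2)cc1`: 4300 nM
compound 2, `CC[C@H](C)[C@H](N)CN(C(=O)[C@@H]1C[C@H]1c1ncccn1)c1ccc(-c2ccccc2)cc1`: 130 nM
compound 3, `CC[C@H](C)[C@H](N)CN(C(=O)[C@@H]1C[C@H]1c1nc(C)cs1)c1ccc(-c2ccccc2)cc1`: 730 nM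

Compound 3 stands second highest of the three numbers in this assay. The nearer gap is a 5.6-fold higher number from compound 2 to compound 3 (0.75 log units; beyond the scatter), the further one a 5.9-fold lower number from compound 1 to compound 3 (0.77 log units; beyond the scatter). The remaining measured step, a 33-fold lower number from compound 1 to compound 2 (1.52 log units; beyond the scatter), ranks the three aryl groups on the saturated ring carbon and is the largest of the set.

Compound 4, `CC[C@H](C)[C@H](N)CN(C(=O)[C@@H]1C[C@H]1c1nc(C)c(C)s1)c1ccc(-c2ccccc2)cc1`, differs from compound 3 by methyl in place of hydrogen on an aromatic carbon, so that 4,5-dimethyl-1,3-thiazol-2-yl replaces 4-methyl-1,3-thiazol-2-yl. Within the data shown here, none of the measured steps adds a substituent to a ring that is otherwise kept; all three exchange one aryl group for another, and they run from modest to large. The step from compound 3 to compound 4 is thus not covered by any measured pair, and a single added methyl is expected to move the number in this assay by less than those aryl exchanges did. The expected step is a 1.0-fold lower number from compound 3 to compound 4 (0.02 log units; within the scatter), which is not clearly beyond the scatter. Compound 4 is expected at 700 nM in this assay, within 250 nM to 2000 nM.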

Compound 4, half-maximal effective concentration: 3600 nM
Compound 4: the middle estimate sits 5.1-fold (0.71 log units) below what was measured; measured number above the stated range.
By their numbers in this assay, from the lowest: compound 2; then compound 3; then compounds 4 and 1 (each within the scatter of the next).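

In this assay, the aromatic carbon next to the ring sulfur of the 4-methyl-1,3-thiazol-2-yl group turns out not to be a neutral place: methyl in place of hydrogen there gives a 4.9-fold higher number from compound 3 to compound 4 (0.69 log units; beyond the scatter), so one added carbon on a ring that is otherwise kept moves the number about as far as the earlier exchanges of one aryl group for another, such as a 5.9-fold lower number from compound 1 to compound 3 (0.77 log units; beyond the scatter). The 4,5-dimethyl-1,3-thiazol-2-yl group no longer stands apart from 4-chlorophenyl, with a 1.2-fold lower number from compound 1 to compound 4 (0.08 log units; within the scatter), while pyrimidin-2-yl stays well ahead of it, with a 28-fold higher number from compound 2 to compound 4 (1.44 log units; beyond the scatter). Nothing at hand accounts for this step.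

Open, from the compounds shown here alone, is whether this carbon of the thiazole ring takes only hydrogen or also carries other groups, such as fluorine, ethyl, methoxy or hydroxymethyl, and how far the number follows their nature. Also open, going by these compounds, is whether a methyl added to the pyrimidin-2-yl ring of compound 2 costs as much as the one added here.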